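The compounds below may be only part of what the source reports. "The series", "measured", "known", "first", "only" and "open" are said of these compounds alone.

Measured compounds in the series:

- compound 1, `Cc1ccc(/C=C/C[C@H]2C[C@@H]([C@@H](O)c3ccccc3)CO[C@@H]2c2ccccc2)cc1C`: in a functional assay on HeLa cells (Homo sapiens) for cytotoxicity, read by WST assay, with a stated time of 48 h (a lower number here means a stronger inhibitor, a higher number a weaker inhibitor), compound 1 gives 10000 nM
- compound 2, `O[C@@H](c1ccccc1)[C@H]1CO[C@H](c2ccccc2)[C@@H](C/C=C/c2cccc(F)c2)C1`: compound 2 gives 8380 nM
- compound 3, `O[C@@H](c1ccccc1)[C@H]1CO[C@H](c2ccccc2)[C@@H](C/C=C/c2ccccc2F)C1`: compound 3 gives 9730 nM

Compound 3 stands second highest of the three numbers; its nearest neighbour is compound 1 and its furthest is compound 2, and both gaps lie within the scatter. The three measured steps are all within the scatter: a 1.2-fold lower number from compound 1 to compound 2 (0.08 log units; within the scatter), a 1.0-fold lower number from compound 1 to compound 3 (0.01 log units; within the scatter) and a 1.2-fold higher number from compound 2 to compound 3 (0.06 log units; within the scatter). Each of them swaps one substituted phenyl for another on the same chain position, and none of them moves the number.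

Compound 4, `O[C@@H](c1ccccc1)[C@H]1CO[C@H](c2ccccc2)[C@@H](C/C=C/C2CCCC2)C1`, differs from compound 3 by cyclopentyl in place of 2-fluorophenyl on a double-bonded chain carbon bound to a double-bonded chain carbon. This is a different kind of change from the measured ones: an aromatic ring leaves and a non-aromatic ring enters. Among the compounds with values here, no measured step covers an aromatic-to-non-aromatic exchange here, so the three steps bear on it only indirectly, in that the chain terminus has so far tolerated variation without any shift beyond the scatter. Given that, the expectation is a step of a 1.0-fold higher number from compound 3 to compound 4 (0.01 log units; within the scatter), that is, no change beyond the scatter, with the risk that the number ends as a limit. Compound 4 is estimated at 10000 nM, with a range from 4500 nM to 25000 nM.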

Compound 4, half-maximal inhibitory concentration: 9330 nM
Compound 4: middle estimate off by 1.1-fold (0.03 log units), on the high side, within the range that was stated.
By their numbers in this assay, from the lowest: compounds 2, 4, 3 and 1 (each within the scatter of the next).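

In this assay, within the data shown here, this is the first exchange of an aromatic ring for a non-aromatic one on a double-bonded chain carbon bound to a double-bonded chain carbon, and cyclopentyl stays within the scatter against 2-fluorophenyl (a 1.0-fold lower number from compound 3 to compound 4 (0.02 log units; within the scatter)), against 3-fluorophenyl (a 1.1-fold higher number from compound 2 to compound 4 (0.05 log units; within the scatter)) and against 3,4-dimethylphenyl (a 1.1-fold lower number from compound 1 to compound 4 (0.03 log units; within the scatter)). Across these four compounds, then, the number at this position does not track whether the ring is aromatic, and no compound goes against this reading, though it holds only for these carbocyclic rings. No supporting measurement bears on this result, so the data give no account of why the number stays in place.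

Still open is what an amine, a carboxylic acid or a longer chain in place of the ring would do at this chain end, since all four groups shown are carbon rings, three of them substituted phenyls. Also open, from the compounds shown here alone, is whether any change at this position can move the number beyond the scatter, or whether changes elsewhere on the shared core would do so.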